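The source may hold more compounds than are shown below. What is called first, only, known or untested is meant among the compounds shown, and "the series" means these compounds.

Among the measured compounds shown here, compound 2 `C=C/C=C\[C@H](C)[C@H](OC(N)=O)[C@@H](C)[C@H](O)[C@@H](C)C/C(C)=C\[C@H](C)[C@@H](O)[C@@H](C)/C=C\CCc1cccc(F)c1` carries a 3-fluorophenyl end group on the shared core; in a functional assay on MCF7 cells (Homo sapiens) for cytotoxicity (on this read-out lower numbers stand for stronger inhibition and higher numbers for weaker inhibition), compound 2 gives 500 nM, one of only two numbers measured so far. For the measured compounds named here, the other belongs to compound 1 `C=C/C=C\[C@H](C)[C@H](OC(N)=O)[C@@H](C)[C@H](O)[C@@H](C)C/C(C)=C\[C@H](C)[C@@H](O)[C@@H](C)/C=C\CCc1cccc(O)c1`, which in this assay gives 390 nM; the sole measured step, a 1.3-fold higher number from compound 1 to compound 2 (0.11 log units; within the scatter), stays within the scatter, so the two compounds stand together. Compound 3 `C=C/C=C\[C@H](C)[C@H](OC(N)=O)[C@@H](C)[C@H](O)[C@@H](C)C/C(C)=C\[C@H](C)[C@@H](O)[C@@H](C)/C=C\CCc1cc(O)cc(O)c1` is the next member: 3,5-dihydroxyphenyl in place of 3-fluorophenyl on a saturated chain carbon, two bonds along the chain from a double-bonded chain carbon. Going by the values given here, the step from compound 1 to compound 2 bears on this change only in part, as it exchanged hydroxy and fluoro on an aromatic carbon without a shift beyond the scatter; the second hydroxy has no measured precedent. Compound 3 is therefore expected to land near compound 2, with a 1.1-fold lower number from compound 2 to compound 3 (0.05 log units; within the scatter) expected to stay within the scatter. Compound 3 is estimated at 450 nM, with a range from 150 nM to 1500 nM.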

Compound 3, half-maximal inhibitory concentration: > 1000 nM
Compound 3 ended at the assay's limit; the forecaster's own chance of this, stated with the estimate: 3%; middle value at least 2.2-fold (0.34 log units) from the limit.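

Compound 3 stands at a limit of this assay, not at a number: the limit of > 1000 nM in this assay, at which 1 of the 3 values shown sits.

Set against the single hydroxy, the added hydroxy gives an at least 2.5-fold higher number from compound 1 to compound 3 (0.40 log units; beyond the scatter), the first step in the series printed as beyond the scatter, so this end group does not tolerate every change on the aromatic ring. Read from the fluoro end, the change gives an at least 2.0-fold higher number from compound 2 to compound 3 (0.30 log units; that floor lies within the scatter), and this floor alone does not separate the two compounds, so the firmer reading comes from the hydroxy pair.

The compounds shown do not tell whether the shift follows the presence of the second hydroxy or its place on the ring. As far as these compounds go, how an amine or a carboxylic acid would read in place of that hydroxy also stays open.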